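Fluorine pattern on the urea aryl of the pyrazole ureas

The compounds below may be only part of what the source reports. "The series", "measured", "known", "first", "only" and "open" are said of these compounds alone.

Measured so far:
compound 1, `CC(C)(C)c1cc(NC(=O)Nc2ccc(F)cc2)n(-c2ccccc2)n1`, -2.2 degrees C
compound 2, `CC(C)(C)c1cc(NC(=O)Nc2cc(C(F)(F)F)cc(C(F)(F)F)c2)n(-c2ccc(Br)cc2)n1`, 0.3 degrees C

In an assay on isolated protein for inhibition of Ephrin type-A receptor 2 (Homo sapiens), read by thermal shift assay, tested at 10 uM (on this read-out higher numbers stand for stronger stabilisation of the target against heat and lower numbers for weaker stabilisation of the target), compound 1 stands lowest of the two numbers; compound 2 sits higher, a gap beyond the scatter. Among the measured compounds shown here, no step between measured compounds differing in one place is available.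

Compound 3, `CC(C)(C)c1cc(NC(=O)Nc2cc(F)cc(F)c2)n(-c2ccccc2)n1`, carries 3,5-difluorophenyl in place of 4-fluorophenyl on an amide-type nitrogen. For the measured compounds named here, no measured pair tells what this change does; the expected step of a number 0.70 degrees C higher from compound 1 to compound 3 (within the scatter) is small, upward if anything, and possibly not beyond the scatter. For compound 3 the estimate is -1.5 degrees C, expected within -4 degrees C to 1 degrees C.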

Compound 3, shift of the target's melting temperature: 2.7 degrees C
Beside the measured number, compound 3's estimate is 4.2 degrees C below it; the whole stated range lies below it.
By their numbers in this assay, from the lowest: compound 1; then compound 2; then compound 3.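

3,5-Difluorophenyl in place of 4-fluorophenyl on the amide-type nitrogen gives the step of a number 4.9 degrees C higher from compound 1 to compound 3 (beyond the scatter) in this assay and is the first one-place comparison in the series. This position therefore responds strongly to the fluorine pattern on the aryl ring while the rest of the structure stays constant.

Open, on these data alone, is whether chlorine atoms or nitrile groups in place of the two fluorine atoms of the 3,5-difluorophenyl would keep this step. Also open, as far as these compounds go, is whether the step carries over to a core with the 4-bromophenyl group of compound 2. Nothing at hand bears on the reason for the step.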